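The source may report more compounds than this note shows. Statements on the series, on what has been measured and on what is new or still open speak of the compounds shown alone.

In a functional assay on U-87MG ATCC cells for antiproliferative activity against U-87 MG (Homo sapiens), read by MTT assay, with a stated time of 72 h (on this read-out lower numbers stand for stronger inhibition and higher numbers for weaker inhibition), compound 1 `Cc1nn(C)c(Oc2cccc(F)c2)c1/C=N\CCCCCOc1cc2oc(=O)cc(C)c2cc1Cl` gives 9870 nM. Compound 2 `Cc1nn(C)c(Oc2ccc(F)cc2)c1/C=N\CCCCCOc1cc2oc(=O)cc(C)c2cc1Cl` reaches only a limit of the assay, > 25000 nM. The change between them, (4-fluorophenyl in place of 3-fluorophenyl on an oxygen on an aromatic ring), brings an at least 2.5-fold higher number from compound 1 to compound 2 (0.40 log units; beyond the scatter); that this step can be stated only as a lower bound is because of the limit of > 25000 nM in this assay, at which 2 of the 3 values shown sit. Compound 3 `Cc1nn(C)c(Oc2cccc(F)c2)c1/C=N\CCCCCCOc1cc2oc(=O)cc(C)c2cc1Cl` likewise returns only a limit of the assay, > 25000 nM. The difference between the core of compound 1 and the core of compound 3 is not broken down here, so their two values are simply set side by side: a number for compound 1 and a limit for compound 3. Compound 4 `Cc1nn(C)c(Oc2ccc(F)cc2)c1/C=N\CCCCCCOc1cc2oc(=O)cc(C)c2cc1Cl` is not yet measured; it differs from compound 3 by 4-fluorophenyl in place of 3-fluorophenyl on an oxygen on an aromatic ring, the same change that was made from compound 1 to compound 2. Since that change gave a larger number, and compound 3 already sits at the limit, the step from compound 3 to compound 4 is expected to be a step that the limit leaves unreadable from compound 3 to compound 4. For compound 4 in this assay the estimated value is 45000 nM, expected to lie between 20000 nM and 120000 nM.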

Compound 4, half-maximal inhibitory concentration: 16700 nM
For compound 4 the middle estimate is 2.7-fold (0.43 log units) above the measured one; the measured number lies below the stated range.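

In this assay, 4-fluorophenyl in place of 3-fluorophenyl on an oxygen on an aromatic ring brings an at least 1.4-fold lower number from compound 3 to compound 4 (0.17 log units; that floor lies within the scatter). Set beside the earlier step, this shows that the effect of the change on the core of compound 1 cannot be carried over to the core of compound 3, where the number moves the other way, and the gap between the two steps is not scatter: the same change on two cores in this assay, an at least 2.5-fold higher number (0.40 log units; beyond the scatter) from compound 1 to compound 2 and an at least 1.4-fold lower number (0.17 log units; that floor lies within the scatter) from compound 3 to compound 4, at least 3.7-fold (0.57 log units) apart, beyond the scatter of two such steps It does not show why the two cores respond differently, and both steps remain bounds rather than exact sizes because each rests on a limit: the limit of > 25000 nM in this assay, at which 2 of the 4 values shown sit.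

The compounds shown leave open whether this difference between the two cores would also appear with an unsubstituted phenyl or a chlorophenyl group on the same oxygen. They also leave open how the 3-fluorophenyl and 4-fluorophenyl groups would compare on a core with a longer chain.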